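This account rests on a few compounds, and the source may have more. Where it says the series, first, only, none or still open, it means among the compounds named here.

In an ADME assay on SW1353 cells (Homo sapiens) for cytotoxicity, read by a luciferase reporter, with a stated time of 30 min (on this read-out lower numbers stand for higher toxicity in this test and higher numbers for lower toxicity in this test), compound 1 `O=C(Nc1ccc(N2CCNCC2)cc1)c1ccc(-c2ccc(Cl)cc2Cl)o1` gives 8100 nM and compound 2 `O=C(Nc1ccc(N2CCNCC2)cc1)c1ccc(-c2ccc(Cl)cc2)s1` gives 8000 nM, two values within the usual scatter of each other. Compound 3 `CC(C)N(C(=O)c1ccc(-c2ccc(Cl)cc2)o1)c1ccc(N2CCNCC2)cc1` returns no exact number, only the limit > 20000 nM. On these data alone, it therefore stands at the limit of > 20000 nM in this assay, at which 1 of the 3 values shown sits, on the side of lower toxicity in this test, and how far beyond that limit its true value lies is unknown.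

Compound 4 `O=C(c1ccc(-c2ccc(Cl)cc2)o1)N(Cc1ccncc1)c1ccc(N2CCNCC2)cc1` keeps the rest of compound 3 but places (pyridin-4-yl)methyl in place of isopropyl on an amide-type nitrogen. For the measured compounds named here, no pair of measured compounds shows what such an exchange does, so the expectation rests on little. Like compound 3, compound 4 has a group on that nitrogen, so a modest move toward lower numbers seems more likely than a large one, and the reading may again be only a limit. The expected change is an at least 1.4-fold lower number from compound 3 to compound 4 (0.15 log units; that floor lies within the scatter). For compound 4 the estimate is 14000 nM, with an expected range from 6500 nM to 20000 nM.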

Compound 4, half-maximal cytotoxic concentration: > 8000 nM
Compound 4 was reported as a limit; the forecaster's own chance of this, stated with the estimate: 35%; the middle value does not contradict the limit.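

For the compounds shown here, compound 3 and compound 4 both return only limits in this assay, and no step between them can be read. On these data alone, what placing (pyridin-4-yl)methyl in place of isopropyl does to this read-out stays open, as does how far each true value lies beyond its limit.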